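This account rests on a few compounds, and the source may have more. Where it says the series, first, only, none or still open, it means among the compounds named here.

Within the data shown here, in a functional assay on HEK293 cells for activation of melanin-concentrating hormone receptor 1 (Rattus norvegicus), read by inositol phosphate accumulation (on this read-out lower numbers stand for an effect already at smaller amounts and higher numbers for an effect only at larger amounts of compound), compound 3 `CC(C)C(=O)NC1CCN(c2ccc3cc(NC(=O)CCc4ccc(C(F)(F)F)cc4)ccc3n2)C1` gives 90 nM, the second highest of the three numbers known. Compound 1 `O=C(CCc1ccc(C(F)(F)F)cc1)Nc1ccc2nc(N3CCC3)ccc2c1` gives 56 nM, and the step of a 1.6-fold higher number from compound 1 to compound 3 (0.21 log units; within the scatter) lies within the scatter. Compound 2 `O=C(CCc1ccc(C(F)(F)F)cc1)Nc1ccc2nc(N3CC4CC3CN4)ccc2c1` gives 490 nM; the step of a 5.4-fold lower number from compound 2 to compound 3 (0.74 log units; beyond the scatter) is beyond the scatter, as is an 8.8-fold higher number from compound 1 to compound 2 (0.94 log units; beyond the scatter). Compound 4 `CNC(=O)NC1CCN(c2ccc3cc(NC(=O)CCc4ccc(C(F)(F)F)cc4)ccc3n2)C1` differs from compound 3 only by methylamino in place of isopropyl on a carbonyl carbon. Among the measured compounds shown here, no measured step touches this carbonyl carbon; the steps known swap the whole ring group on the aromatic carbon, so they guide only indirectly. The closest guide, a 1.6-fold higher number from compound 1 to compound 3 (0.21 log units; within the scatter), suggests that this part of the molecule moves the number little. A step of a 1.3-fold higher number from compound 3 to compound 4 (0.12 log units; within the scatter) in this assay is therefore expected, within the scatter. Compound 4 is estimated at 120 nM, with a range from 40 nM to 400 nM.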

Compound 4, half-maximal effective concentration: 30 nM
Beside the measured number, compound 4's estimate is 4.0-fold (0.60 log units) above it, and the stated range ends above it.
By their numbers in this assay, from the lowest: compounds 4, 1 and 3 (each within the scatter of the next, the first and the last beyond it); then compound 2.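

In this assay, the group on the carbonyl carbon proves to matter: methylamino in place of isopropyl gives a 3.0-fold lower number from compound 3 to compound 4 (0.48 log units; beyond the scatter), something the earlier swaps of whole ring groups could not show. The whole-group comparisons give a 16-fold lower number from compound 2 to compound 4 (1.21 log units; beyond the scatter), the largest step here, and a 1.9-fold lower number from compound 1 to compound 4 (0.27 log units; within the scatter), which stays within the scatter. Nothing measured here explains the effect of the methylamino group. From the compounds shown here alone, whether dimethylamino, ethylamino or methoxy on the same carbonyl carbon would keep this lower number stays open.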